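Bigger Chain End on a Sulfonyl Carbamate Series

The compounds below may be only part of what the source reports. "The series", "measured", "known", "first", "only" and "open" are said of these compounds alone.

Measured so far:
compound 1, `CCCCN(CCCC)C(=O)CCCOC(=O)c1c(CC)nc(CCC)n1Cc1ccc(-c2ccccc2-c2nn[nH]n2)cc1`: 500 nM
compound 2, `CCCOC(=O)NS(=O)(=O)c1ccccc1-c1ccc(Cn2c(CCC)nc(CC)c2C(=O)OCc2cccc(C(=O)c3ccccc3)c2)c(F)c1`: 10 nM
compound 3, `CCCc1nc(CC)c(C(=O)OCc2ccccc2C(=O)c2ccccc2)n1Cc1ccc(-c2ccccc2S(=O)(=O)NC(=O)OCCc2ccccc2)cc1F`: 0.69 nM

In an assay on isolated protein for binding affinity to Type-2 angiotensin II receptor (Homo sapiens) (on this read-out higher numbers stand for weaker inhibition and lower numbers for stronger inhibition), compound 2 gives 10 nM, the second highest of the three numbers. Compound 3 gives the lower 0.69 nM, and compound 1 the higher 500 nM; both gaps lie beyond the usual scatter. Compound 4, `CCCc1nc(CC)c(C(=O)OCc2cccc(C(=O)c3ccccc3)c2)n1Cc1ccc(-c2ccccc2S(=O)(=O)NC(=O)OCCC(C)C)cc1F`, differs from compound 2 in one place: isopropyl in place of methyl on a saturated chain carbon, two bonds along the chain from an oxygen next to a carbonyl group. Going by the values given here, no measured pair shows exactly this change, so the size of the step is open. Compound 3 also carries a larger group on that chain but differs from compound 2 elsewhere as well. Compound 3 gives 0.69 nM, which hints at a modest move to a lower number, not assuredly beyond scatter. Compound 4 is expected to give 5 nM, in the range 1.5 nM to 20 nM. The expected step is a 2.0-fold lower number from compound 2 to compound 4 (0.30 log units; within the scatter).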

Compound 4, half-maximal inhibitory concentration: 0.9 nM
Compound 4: middle estimate off by 5.6-fold (0.74 log units), on the high side; the whole stated range lies above it.
By their numbers in this assay, from the lowest: compounds 3 and 4 (each within the scatter of the next); then compound 2; then compound 1.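

Putting isopropyl in place of methyl at this spot in this assay gives an 11-fold lower number from compound 2 to compound 4 (1.05 log units; beyond the scatter). Going by these compounds alone, the first measured step at this chain end therefore shows that the position responds strongly, even though the change adds only carbon, with no ring and no hydrogen-bond donors or acceptors. No measured evidence accounts for the size of this step. Going by these compounds, whether an amine, a hydroxyl group or a longer chain at this carbon would give a similar number remains open. So does whether the same step would appear with other changes elsewhere on the molecule.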